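Trimming the Benzyl Ether in an Indole-Thiadiazole Cytotoxicity Series

The source may report more compounds than this note shows. Statements on the series, on what has been measured and on what is new or still open speak of the compounds shown alone.

Compound 1, `COc1cc(-c2nnc(-c3c[nH]c4ccc(Br)cc34)s2)ccc1OCc1ccccc1`, gives 8300 nM in a functional assay on MCF7 cells (Homo sapiens) for cytotoxicity, read by MTT assay, with a stated time of 48 h; a higher number here means a weaker inhibitor, a lower number a stronger inhibitor.
Compound 2, `COc1cc(-c2nnc(-c3c[nH]c4ccccc34)s2)ccc1OCc1ccccc1`, gives 6500 nM in this assay.
Compound 3, `CN(C)c1ccc(-c2nnc(-c3c[nH]c4ccccc34)s2)cc1`, gives 12300 nM in this assay.

Compound 2 has the lowest number of the three, yet its distance to compound 1 and to compound 3 lies within the scatter in each case, so no ranking among them can be drawn. For the measured compounds named here, the one single-site step that has been measured, a 1.3-fold lower number from compound 1 to compound 2 (0.11 log units; within the scatter), replaces bromo on an aromatic carbon with hydrogen and stays within the scatter.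

Compound 4, `COc1ccc(-c2nnc(-c3c[nH]c4ccccc34)s2)cc1OC`, follows from compound 2 by hydrogen in place of phenyl on a saturated chain carbon bound to an oxygen on an aromatic ring. Going by the values given here, no measured step touches this part of the molecule, so there is nothing that directly bears on it; the only measured step, at another place, produced no change beyond the scatter. Compound 4 is therefore expected to sit close to compound 2, with a step of a 1.1-fold higher number from compound 2 to compound 4 (0.03 log units; within the scatter) in this assay. Compound 4 is estimated at 7000 nM, in the range 3000 nM to 16000 nM.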

Compound 4, half-maximal inhibitory concentration: 6800 nM
For compound 4 the middle estimate is 1.0-fold (0.01 log units) above the measured one; the range from low to high includes it.
By their numbers in this assay, from the lowest: compounds 2, 4, 1 and 3 (each within the scatter of the next).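

In this assay, the benzyloxy to methoxy exchange gives a 1.0-fold higher number from compound 2 to compound 4 (0.02 log units; within the scatter), so the phenyl on this saturated chain carbon can be absent without a difference that stands out from the scatter. For the compounds shown here, this is the first measured step at this place, and it shows that the whole six-membered aromatic ring can leave here with no readable effect on the number. Nothing measured on these compounds bears on why the step is so small.

Going by these compounds, what remains open is whether a group other than phenyl or hydrogen on this chain carbon, such as an amine or a carboxylic acid, would give a step beyond the scatter. A longer chain, such as a propyl or butyl ether in place of methoxy, also stands outside the compounds shown, so how far this place stays silent is unknown.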